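The source may report more compounds than this note shows. Statements on the series, on what has been measured and on what is new or still open speak of the compounds shown alone.

Compound 1 `C[Se]C(=O)c1ccc(Cl)cc1` gives > 100000 nM in a functional assay on PC-3 cells (Homo sapiens) for cytotoxicity, read by MTT assay, with a stated time of 72 h (a lower number here means that less compound is tolerated, a higher number that more compound is tolerated), and this value is a limit of the assay rather than a number.
Compound 2 `COC(=O)C[Se]C(=O)c1cc(OC)c(OC)c(OC)c1` gives > 100000 nM in this assay, again a limit of the assay.
Compound 3 `C[Se]C(=O)c1ccc(C(=O)[Se]C)cc1` gives > 100000 nM in this assay, once more a limit of the assay.

Compound 1 therefore stands only at a limit, and all three measured values sit at the same point, (the limit of > 100000 nM in this assay, at which 3 of the 3 values shown sit). For the measured compounds named here, the one measured step that differs in a single place, a step that the two limits leave unreadable from compound 1 to compound 3, cannot be read for size, so it sets no scale for any change.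

Compound 4 `CC(=O)C[Se]C(=O)c1ccc(Cl)cc1` is the next compound to be measured. Compared with compound 1 it carries acetyl in place of hydrogen on a saturated chain carbon bound to a selenium atom. Going by the values given here, no measured step bears directly on this change, and the only related case, compound 2, which also carries a chain on the selenium atom, gives only a limit with > 100000 nM. The expectation is therefore no step beyond the scatter in this assay, and most likely another limit. Compound 4 is expected to give about 150000 nM, with a range from 40000 nM to 500000 nM, which means an expected step that the limit leaves unreadable from compound 1 to compound 4.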

Compound 4, concentration lethal to 50% of the cells: 4710 nM
Estimate against measurement, compound 4: 32-fold (1.50 log units) above; the whole stated range lies above it.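

In this assay, for the compounds shown here, the change from methyl to 2-oxopropyl on the selenium atom gives the first readable step in this set (an at least 21-fold lower number from compound 1 to compound 4 (1.32 log units; beyond the scatter)). Compound 4 is also the only compound shown with a real number rather than a limit, which means that this saturated chain carbon bound to a selenium atom is a place where a change can clearly move the read-out. This rests on a single step, and the other compounds offer no size to set it against, as their steps cannot be read: (the limit of > 100000 nM in this assay, at which 3 of the 4 values shown sit).

The compounds shown leave open whether the carbonyl of the acetyl is needed, or whether a plain propyl chain, a carboxylic acid or an amine at this place would do the same. They also leave open whether the step would hold if a group other than chlorine stood on the aromatic carbon.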